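Amide Nitrogen Swap on a Quinoxaline Solubility Series

A few compounds are considered here, and "the series" means these few. Any claim that something is new, unique, unknown or untested is made for them only; others in the source may bear on it.

Compound 1 `Cn1ccc2ccc(-c3cc(Nc4ccccc4S(N)(=O)=O)cc4nccnc34)cc21` — 6 ug/mL
Compound 2 `Cn1cc(NC(=O)c2ccncc2Nc2cc(-c3ccc4ccn(C)c4c3)c3nccnc3c2)cn1` — 2 ug/mL

Of the compounds shown here, two have been measured in a physicochemical assay for solubility, read by spectrophotometry, measured as kinetic solubility, at pH 8, tested at 500 uM; a higher number here means a more soluble compound, a lower number a less soluble compound. Compound 1 gives 6 ug/mL, and compound 2 gives 2 ug/mL, which is the lower of the two numbers; the gap between them is beyond the usual scatter, so compound 2 stands as the less soluble of the pair.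

Compound 3 `CC(=O)N1CCC(NC(=O)c2ccncc2Nc2cc(-c3ccc4ccn(C)c4c3)c3nccnc3c2)C1` has not yet been measured. It differs from compound 2 in one place: 1-acetylpyrrolidin-3-yl in place of 1-methyl-1H-pyrazol-4-yl on an amide-type nitrogen. Within the data shown here, no step between measured compounds covers this change, so the expectation rests on compound 2 alone. A small rise in this assay is expected, of a size that may not clear the scatter, since compound 2 starts from 2 ug/mL. Compound 3 is therefore expected to give 4 ug/mL, within a range of 1.5 ug/mL to 12 ug/mL. The expected step is a 2.0-fold higher number from compound 2 to compound 3 (0.30 log units; within the scatter).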

Compound 3, solubility: 253 ug/mL
Compound 3: middle estimate off by 63-fold (1.80 log units), on the low side; the whole stated range lies below it.
By their numbers in this assay, from the lowest: compound 2; then compound 1; then compound 3.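

In this assay the substituent on the amide-type nitrogen turns out to be a place where a single change can move the number very far: 1-acetylpyrrolidin-3-yl in place of 1-methyl-1H-pyrazol-4-yl gives a 130-fold higher number from compound 2 to compound 3 (2.10 log units; beyond the scatter) in one move. The change replaces a five-membered aromatic ring with a five-membered non-aromatic ring and brings in an acetyl carbonyl, while the rest of the structure stays the same. No measurement shown here explains a step of this size.

Compounds 2 and 3 cannot separate the loss of the aromatic ring from the gain of the acetyl group. On these data alone, how a free pyrrolidine amine or a piperidine ring on this nitrogen would read in this assay remains open.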